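From hydroxymethyl to 2-carboxyethenyl at the assay limit

The compounds below may be only part of what the source reports. "The series", "measured", "known", "first", "only" and "open" are said of these compounds alone.

In a functional assay on A2780 cells (Homo sapiens) for antiproliferative activity, read by sulforhodamine B assay, with a stated time of 48 h (on this read-out lower numbers stand for stronger inhibition of growth and higher numbers for weaker inhibition of growth), compound 1 (`CC(C)(C)[Si](C)(C)OC[C@H]1OCCC[C@H]1O[Si](C)(C)C(C)(C)C`) gives > 100000 nM, which is a limit. Compound 2 (`CC(C)(C)[Si](C)(C)O[C@@H]1CCCO[C@@H]1CO`) gives > 100000 nM, also a limit and no number. Compound 3 (`COC(=O)/C=C/[C@H]1OCCC[C@H]1O`) gives > 100000 nM, again a limit. Going by the values given here, the series so far therefore rests on (the limit of > 100000 nM in this assay, at which 3 of the 3 values shown sit).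

Compound 4 (`CC(C)(C)[Si](C)(C)O[C@@H]1CCCO[C@@H]1/C=C/C(=O)O`) differs from compound 2 by 2-carboxyethenyl in place of hydroxymethyl on a saturated ring carbon. Among the compounds with values here, the only measured step is a step that the two limits leave unreadable from compound 1 to compound 2, so it offers no size to carry over, and no compound yet shows a number in this assay. No step beyond the scatter is expected, and no direction can be assigned. The expected step is a number no higher from compound 2 to compound 4 (the limit leaves the size open). For compound 4 the estimated value is 100000 nM, with an expected range of 40000 nM to 200000 nM.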

Compound 4, concentration for 50% growth inhibition: > 100000 nM
Compound 4: only a limit was reported; the forecaster's own chance of this, stated with the estimate: 80%; the middle value sits exactly at the limit.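

Compound 2 and compound 4 both sit at the limit, so no step can be read between them. The compounds shown leave open which change to the shared core, if any, would give a number rather than a limit: the limit of > 100000 nM in this assay, at which 4 of the 4 values shown sit.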